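Shifting Two Fluorines on the Pendant Aromatic Ring

The compounds below may be only part of what the source reports. "The series", "measured", "known", "first", "only" and "open" are said of these compounds alone.

Among the compounds with values here, compound 2 `N#Cc1c(N2CCC(c3ccc(F)cc3F)CC2)ccn(CC2CC2)c1=O` gives 272% in a functional assay on CHO cells for positive allosteric modulation of metabotropic glutamate receptor 2 (Homo sapiens), with a stated time of 30 min (on this read-out higher numbers stand for larger maximal responses and lower numbers for smaller maximal responses), the higher of the two numbers so far. Within the data shown here, compound 1 `N#Cc1c(N2CCC(c3ccccc3Cl)CC2)ccn(CC2CC2)c1=O` gives 259% in this assay, and the only measured step, a number 13 percentage points higher from compound 1 to compound 2 (beyond the scatter), was modest. Compound 3 `N#Cc1c(N2CCC(c3cc(F)cc(F)c3)CC2)ccn(CC2CC2)c1=O` differs from compound 2 in one way: 3,5-difluorophenyl in place of 2,4-difluorophenyl on a saturated ring carbon. Among the measured compounds shown here, no measured step rearranges fluorines on the same aromatic ring, and the one change to that ring produced only a modest shift, so a step of no more than the scatter is expected. The expected step is a number 17 percentage points lower from compound 2 to compound 3 (beyond the scatter). Compound 3 is therefore estimated at 255%, between 210% and 300%.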

Compound 3, largest response reached (Emax), in percent of the reference or control that the assay uses: 234%
The estimate for compound 3 lay 21 percentage points above the measured number; low and high end bracket the measured number.
By their numbers in this assay, from the lowest: compound 3; then compound 1; then compound 2.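

At this position on the saturated ring, the arrangement of the fluorines counts and not just their number: the same atoms joined differently give a number 38 percentage points lower from compound 2 to compound 3 (beyond the scatter) in this assay, a large step. Against the single chlorine, the 3,5-difluorophenyl group also loses ground, with a number 25 percentage points lower from compound 1 to compound 3 (beyond the scatter) as a modest step. Only the 2,4-difluorophenyl group improves on 2-chlorophenyl here.

Going by these compounds, how a methoxy group or a trifluoromethyl group on this aromatic ring would fare remains open. Nothing available explains why moving the fluorines changes the maximal response.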